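The compounds below may be only part of what the source reports. "The series", "measured", "known", "first", "only" and "open" are said of these compounds alone.

Measured compounds:
- compound 1, `O=C(Nc1ccc(Oc2ccnc3[nH]ccc23)cc1)c1cn(-c2ccc(Cl)cc2)c2ccccc2c1=O`, gives 1590 nM in a functional assay on MCF7 cells (Homo sapiens) for inhibition, read by MTT assay, with a stated time of 72 h; a lower number here means a stronger inhibitor, a higher number a weaker inhibitor
- compound 2, `Cn1ccc2c(Oc3ccc(NC(=O)c4cn(-c5ccc(Cl)cc5)c5ccccc5c4=O)cc3F)ccnc21`, gives 2120 nM in this assay
- compound 3, `O=C(Nc1ccc(Oc2ccnc3[nH]ccc23)c(F)c1)c1cn(-c2ccc(Cl)cc2)c2ccccc2c1=O`, is reported only as "not determined" (no result reported) in this assay, that is, it has no number there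

Compound 1 and compound 2 share a common core and land close to each other in this assay; the gap between their two values is within the usual scatter, so no order between them can be read. Compound 3 carries the same core with a fluorine on the central ring, but for it no result was reported, so on the numbers shown compound 3 stands nowhere and can only be placed by analogy with compound 1 and compound 2.

Compound 4, `COc1ccc(-n2cc(C(=O)Nc3ccc(Oc4ccnc5[nH]ccc45)c(F)c3)c(=O)c3ccccc32)cc1`, differs from compound 3 in one place: methoxy in place of chloro on an aromatic carbon. Among the measured compounds shown here, no measured pair shows the effect of this exchange, so there is no basis to expect a shift in either direction beyond the scatter in this assay. Compound 4 is therefore expected to fall near the range of its relatives, at about 2500 nM, with a plausible span from 600 nM to 10000 nM.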

Compound 4, half-maximal inhibitory concentration: 6620 nM
Beside the measured number, compound 4's estimate is 2.6-fold (0.42 log units) below it; low and high end bracket the measured number.
By their numbers in this assay, from the lowest: compounds 1 and 2 (each within the scatter of the next); then compound 4.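

No step can be read from compound 4 at 6620 nM, since its one-place neighbour, compound 3, has no number in this assay. From the compounds shown here alone, what the change from 4-chlorophenyl to 4-methoxyphenyl does to the value stays open. No other finding shown bears on this result.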